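The compounds below may be only part of what the source reports. "The series", "measured", "known", "first", "only" and "open" are said of these compounds alone.

Measured compounds:
compound 1 `CCc1cc(C(C)=O)c(O)cc1OCCCC(C)(C)C(=O)O`: 43%
compound 2 `CCc1cc(C(C)=O)c(O)cc1OCCCC(C)(C)C(N)=O`: 51%

In an assay on isolated protein for binding affinity to leukotriene B4 receptor 1 (Homo sapiens), tested at 1 uM (on this read-out higher numbers stand for more inhibition at the one concentration tested (going by the name of the read-out) and lower numbers for less inhibition), compound 1 gives 43% and compound 2 gives 51%. Compound 2 therefore has the higher of the two numbers, yet the step of a number 8 percentage points higher from compound 1 to compound 2 (within the scatter) is within the scatter, so on these numbers the two compounds cannot be told apart. Compound 3 `CCc1cc(C(C)=O)c(O)cc1OCCCCCCSC` has not yet been measured in this assay. It differs from compound 2 in one place: 3-(methylsulfanyl)propyl in place of 1-carbamoyl-1-methylethyl on a saturated chain carbon, three bonds along the chain from an oxygen on an aromatic ring. Within the data shown here, the only measured step that touches this part of the molecule is a number 8 percentage points higher from compound 1 to compound 2 (within the scatter), which swapped amino for hydroxy on a carbonyl carbon and left the number essentially where it was. Among the measured compounds shown here, that step, however, kept the carbonyl; the change to compound 3 removes the 1-carbamoyl-1-methylethyl group entirely and brings in 3-(methylsulfanyl)propyl, and no measured pair shows what such a change does. For the measured compounds named here, with a within-scatter step as the only guide, the expected step of a number 6 percentage points lower from compound 2 to compound 3 (within the scatter) is small. Compound 3 is thus estimated at 45%, with a wide range from 25% to 65% to reflect the thin evidence.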

Compound 3, a percentage reported as inhibition, at one concentration (the size of the read-out at that concentration, not a potency): 14%
For compound 3 the middle estimate is 31 percentage points above the measured one; measured number outside the range, below it.
By their numbers in this assay, from the lowest: compound 3; then compounds 1 and 2 (each within the scatter of the next).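

In this assay, among these compounds, this change at the end of the chain is the first to move the number by more than the scatter. Putting 3-(methylsulfanyl)propyl in place of 1-carbamoyl-1-methylethyl gives a number 37 percentage points lower from compound 2 to compound 3 (beyond the scatter), and putting it in place of 1-carboxy-1-methylethyl gives a number 29 percentage points lower from compound 1 to compound 3 (beyond the scatter), so the fall appears from both starting points, whereas the earlier swap of amino for hydroxy on the carbonyl carbon left the two compounds indistinguishable and therefore suggested that the end group could vary freely, a reading that holds only while the carbonyl stays in place. No measured evidence on why the number falls is available here.

The compounds shown leave open whether the fall goes with losing the carbonyl or with bringing in the sulfur, as both changes sit in the same step. Going by these compounds, how a chain ending in an amine, in a hydroxy group or in a plain alkyl group with no sulfur would read in this place also remains open, and such ends could help separate those two changes.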